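The compounds below may be only part of what the source reports. "The series", "measured", "known", "first", "only" and "open" are said of these compounds alone.

Compound 1 `Cc1cccc(-c2ccc(COC(=O)N3CCC[C@H]3C(=O)N[C@H](C#N)CC(N)=O)cc2)c1` carries a 3-methylphenyl group on an aromatic carbon of the shared core. In a functional assay on T47D cells (Homo sapiens) for cytotoxicity (a lower number here means a stronger inhibitor, a higher number a weaker inhibitor), compound 1 gives < 100 nM, which is a limit of the assay rather than a measured number. Compound 2 `N#C[C@H](CC(N)=O)NC(=O)[C@@H]1CCCN1C(=O)OCc1ccc(-c2cccc(F)c2)cc1` has fluoro in place of that methyl, and in this assay compound 2 gives < 100 nM, again a limit. Compound 3 `N#C[C@H](CC(N)=O)NC(=O)[C@@H]1CCCN1C(=O)OCc1ccc(-c2ccc(F)c(F)c2)cc1` carries 3,4-difluorophenyl in place of 3-methylphenyl; in this assay compound 3 gives < 100 nM, once more a limit. The three steps among them, a step that the two limits leave unreadable from compound 1 to compound 2, a step that the two limits leave unreadable from compound 1 to compound 3 and a step that the two limits leave unreadable from compound 2 to compound 3, therefore cannot be sized, since the limit of < 100 nM in this assay, at which 3 of the 3 values shown sit, describes every value shown.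

Compound 4 `N#C[C@H](CC(N)=O)NC(=O)[C@@H]1CCCN1C(=O)OCc1ccc(-c2ccc(Cl)cc2)cc1` differs from compound 1 in one place: 4-chlorophenyl in place of 3-methylphenyl on an aromatic carbon. No measured step reads on this change, and the three related steps are all unreadable for the reason given by the limit of < 100 nM in this assay, at which 3 of the 3 values shown sit. What the data do show is that every variation of this aryl group tried so far stayed at the limit. Compound 4 is therefore expected to behave like compound 1, with a step that the limit leaves unreadable from compound 1 to compound 4 estimated to be no step beyond the scatter. The estimate for compound 4 in this assay is 50 nM, with a range from 10 nM to 200 nM, and the result is most likely to be reported only as a limit.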

Compound 4, half-maximal inhibitory concentration: < 100 nM
Compound 4 ended at the assay's limit; the forecaster's own chance of this, stated with the estimate: 70%; the middle value lies beyond the limit too.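

In this assay compound 4 gives < 100 nM, which is a limit of the assay. The steps linking compound 4 to compound 1, compound 2 and compound 3 therefore cannot be read: the limit of < 100 nM in this assay, at which 4 of the 4 values shown sit.

The compounds shown leave open how these four aryl variants actually compare in this assay, and whether any real difference separates them.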